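The source may report more compounds than this note shows. Statements on the series, on what has been measured and on what is new or still open speak of the compounds shown alone.

Compound 1 `C=CCc1ccccc1OCC1=NCCN1` and compound 2 `c1ccc(OCC2=NCCN2)c(CC2CC2)c1` share a core and differ only in the chain on the aromatic ring. In an assay on isolated protein for binding affinity to Alpha-2C adrenergic receptor (Homo sapiens) (on this read-out higher numbers stand for weaker inhibition and lower numbers for stronger inhibition), compound 1 gives 70.8 nM, and compound 2 gives 631 nM. Among the compounds with values here, of the two numbers known, compound 2 has the higher one, and the only step measured, an 8.9-fold higher number from compound 1 to compound 2 (0.95 log units; beyond the scatter), is the one that separates it from compound 1. Compound 3 `c1ccc(OC2CC2)c(OCC2=NCCN2)c1` keeps the three-membered ring but changes how it is joined to the ring: cyclopropyloxy in place of cyclopropylmethyl on an aromatic carbon. Within the data shown here, no measured pair tests this kind of exchange, a chain carbon giving way to an oxygen on the aromatic carbon, so the one step known bears on it only indirectly, by showing that this part of the molecule moves this assay by a modest amount when altered. A step of similar or smaller size is therefore expected for compound 3, with no firm direction, and the estimate leans toward a number close to that of compound 2: compound 3 is expected to give 500 nM, between 130 nM and 2000 nM, which means an expected step of a 1.3-fold lower number from compound 2 to compound 3 (0.10 log units; within the scatter).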

Compound 3, inhibition constant: 794 nM
Compound 3: middle estimate off by 1.6-fold (0.20 log units), on the low side, within the range that was stated.
By their numbers in this assay, from the lowest: compound 1; then compounds 2 and 3 (each within the scatter of the next).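

In this assay the exchange of cyclopropylmethyl for cyclopropyloxy on the aromatic carbon comes out as a 1.3-fold higher number from compound 2 to compound 3 (0.10 log units; within the scatter) and stays within the scatter, so at this position the two values do not separate an oxygen from a chain carbon as the link to the three-membered ring. This was a kind of change that the earlier pair did not test. Measured against allyl, cyclopropyloxy gives an 11-fold higher number from compound 1 to compound 3 (1.05 log units; beyond the scatter) and lies beyond the scatter, as does cyclopropylmethyl with an 8.9-fold higher number from compound 1 to compound 2 (0.95 log units; beyond the scatter) and so, among these three compounds, allyl stands apart from both groups carrying the three-membered ring, however that ring is joined. No evidence is given that would explain this separation.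

The compounds shown leave open whether the allyl result depends on its carbon-carbon double bond, which a saturated propyl chain on the same aromatic carbon would test. They also leave open how far this position accepts other groups, such as a longer chain like butyl, a simple methoxy or an amine, and whether any of these would match or pass allyl.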